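The compounds below may be only part of what the source reports. "The series", "measured", "known", "first", "only" and "open" are said of these compounds alone.

Measured compounds:
Compound 1, `CC(C)OC(=O)N1CCC(n2ncc3cc(-c4ccc(S(C)(=O)=O)cc4)ncc32)CC1`, gives 0.67 ug/mL.
Compound 2, `CC(C)(OC(=O)N1CCC(n2ncc3cc(-c4ccc(S(C)(=O)=O)cc4F)ncc32)CC1)C(F)F`, gives < 0.06 ug/mL.

Both compounds were tested in a physicochemical assay for solubility, in phosphate buffer, measured as thermodynamic solubility, at pH 6.8; on this read-out higher numbers stand for higher solubility and lower numbers for lower solubility. Compound 1 gives a measurable number. For compound 2 the reading is not a number but a limit of the assay, (the limit of < 0.06 ug/mL in this assay, at which 1 of the 2 values shown sits), so compound 2 stands at the bottom of what can be resolved. The two compounds differ in more than one place, so their values only show that compound 2 is at or beneath the resolvable range while compound 1 is inside it.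

Compound 3, `CCc1cnc(N2CCC(n3ncc4cc(-c5ccc(S(C)(=O)=O)cc5F)ncc43)CC2)nc1`, has not yet been measured in this assay. Its change from compound 2 is 5-ethylpyrimidin-2-yl in place of (1-(difluoromethyl)-1-methylethoxy)carbonyl on an amine nitrogen in a ring. For the measured compounds named here, no step between measured compounds covers this kind of exchange, so no measured precedent gives its size. A modest rise, perhaps beyond the usual scatter, is expected, since a reading at the limit leaves room only upward or level. Compound 3 is expected to give 0.2 ug/mL in this assay, within 0.04 ug/mL to 1.5 ug/mL, which corresponds to an expected at least 3.3-fold higher number from compound 2 to compound 3 (0.52 log units; beyond the scatter).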

Compound 3, solubility: 0.34 ug/mL
Beside the measured number, compound 3's estimate is 1.7-fold (0.23 log units) below it; low and high end bracket the measured number.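

In this assay, placing 5-ethylpyrimidin-2-yl instead of (1-(difluoromethyl)-1-methylethoxy)carbonyl on the amine nitrogen in the ring gives the first step read at this position, an at least 5.6-fold higher number from compound 2 to compound 3 (0.75 log units; beyond the scatter). The reading for compound 2 is a limit of the assay and not a number: the limit of < 0.06 ug/mL in this assay, at which 1 of the 3 values shown sits. The step therefore has a lower bound only, and its full size cannot be read, but it does show that this position can carry an aromatic ring with 2 hetero atoms in place of an open group with a carbonyl while compound 3 gives a reading inside the resolvable range.

The exchange replaces the whole group at once, so the compounds shown cannot separate what the pyrimidine ring, the ethyl group or the departing carbonyl each contribute, nor say whether the same exchange would give a similar step on the core of compound 1. On these data alone, whether a morpholine ring, a hydroxyl group on the ethyl chain or an amine on the pyrimidine ring would carry the number higher also remains open.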